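Three limits and a thiophene swap

The source may hold more compounds than are shown below. What is called first, only, known or untested is meant among the compounds shown, and "the series" means these compounds.

- compound 1 `O=C(NO)c1ccc(/C=C/c2ccnc(-c3ccc(F)cc3)c2)cc1`: > 10000 nM
- compound 2 `O=C(NO)c1ccc(/C=C/c2ccnc(-c3ccc(C(F)(F)F)cc3)c2)cc1`: > 10000 nM
- compound 3 `O=C(NO)c1ccc(/C=C/c2cc(-c3ccc(C(F)(F)F)cc3)ncc2F)cc1`: > 10000 nM

The measurements come from a functional assay on MGC-803 cells (Homo sapiens) for antiproliferative activity, read by CellTiter-Glo, with a stated time of 72 h; on this read-out lower numbers stand for stronger inhibition and higher numbers for weaker inhibition. Compound 1 gives > 10000 nM, which is a limit and not a number. It has no readable place among the measured compounds, which share one result: the limit of > 10000 nM in this assay, at which 3 of the 3 values shown sit.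

Compound 4 `O=C(NO)c1ccc(/C=C/c2ccnc(-c3ccsc3)c2)cc1` differs from compound 1 at one place: thiophen-3-yl in place of 4-fluorophenyl on an aromatic carbon. In words, thiophen-3-yl stands in place of 4-fluorophenyl on an aromatic carbon.

Within the data shown here, two measured steps bear on this change. The change on the same substituent gives a step that the two limits leave unreadable from compound 1 to compound 2, and the added fluoro gives a step that the two limits leave unreadable from compound 2 to compound 3. Neither has a size that can be carried over, so no direction is expected in this assay and no step beyond the scatter. The expected change is a step that the limit leaves unreadable from compound 1 to compound 4. Compound 4 is estimated at 12000 nM, with an expected range from 3000 nM to 40000 nM, and it is expected that the assay may again report only a limit.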

Compound 4, half-maximal inhibitory concentration: 3680 nM
The estimate for compound 4 lay 3.3-fold (0.51 log units) above the measured number, and the stated range covers the measured number.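

Thiophen-3-yl on the aromatic carbon next to the ring nitrogen gives the first readable number in the set: in this assay, its exchange for 4-fluorophenyl gives an at least 2.7-fold lower number from compound 1 to compound 4 (0.43 log units; beyond the scatter). Among these compounds, the steps among compound 1, compound 2 and compound 3 cannot be read, so this is the first sign that the group at this place can move the result, and the step size is only a floor, since the starting value is a limit. Compound 4 alone stands clear of the result that the others share: the limit of > 10000 nM in this assay, at which 3 of the 4 values shown sit.

The exchange alters ring size and ring atoms together, so the compounds shown do not separate the effect of the sulfur-containing ring from that of the smaller group. Going by these compounds, whether a furan-3-yl or a morpholine at this place, or the fluoro of compound 3 combined with thiophen-3-yl, would lower the number further stays open.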